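The source may hold more compounds than are shown below. What is called first, only, known or untested is meant among the compounds shown, and "the series" means these compounds.

Measured compounds:
Compound 1 `Fc1ccc(Nc2cc3[nH]c(-c4ccc(F)c(F)c4)nc3cn2)nc1` — in a physicochemical assay for solubility, using the shake flask method, in phosphate buffer, measured as kinetic solubility, with a stated time of 20 h, at pH 6.5 (a higher number here means a more soluble compound, a lower number a less soluble compound), compound 1 gives < 5000 nM, a limit of the assay.
Compound 2 `Fc1ccnc(Nc2cc3[nH]c(-c4ccc(F)c(F)c4)nc3cn2)c1` — in this assay compound 2 gives < 5000 nM, again a limit and not a number.

Compound 2 therefore stands at the lower edge of what this assay can read, with no numerical value of its own. Among the compounds with values here, the one measured step, a step that the two limits leave unreadable from compound 1 to compound 2, stays unreadable, since the limit of < 5000 nM in this assay, at which 2 of the 2 values shown sit, marks the point where both values sit. Compound 3 `O=C(O)c1ccc(Nc2cc3[nH]c(-c4ccc(F)c(F)c4)nc3cn2)nc1` is reached from compound 2 by the change (5-carboxypyridin-2-yl in place of 4-fluoropyridin-2-yl on a nitrogen on an aromatic ring). No measured step touches a carboxylic acid in this series, so nothing shown bears directly on the move from compound 2 to compound 3; the pair of limits only says that the fluoropyridines are both poorly soluble in this assay. Compound 3 is expected to move upward from compound 2 by an at least 3.0-fold higher number from compound 2 to compound 3 (0.47 log units; beyond the scatter), an expectation rather than anything the data prove. Compound 3 is estimated at 15000 nM in this assay, within a range from 3000 nM to 80000 nM.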

Compound 3, solubility: 7000 nM
Estimate against measurement, compound 3: 2.1-fold (0.33 log units) above; the measured number falls inside the stated range.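

In this assay, within the data shown here, compound 3 gives 7000 nM, the first value that is a number and not a limit, so this place on a nitrogen on an aromatic ring now has one readable point. With 5-carboxypyridin-2-yl in place of 4-fluoropyridin-2-yl the data give an at least 1.4-fold higher number from compound 2 to compound 3 (0.14 log units; that floor lies within the scatter), and with carboxy in place of fluoro on an aromatic carbon they give an at least 1.4-fold higher number from compound 1 to compound 3 (0.14 log units; that floor lies within the scatter). From the compounds shown here alone, each of these steps is only a floor, and its true size stays unknown, because the starting point of both steps is a limit and not a number: the limit of < 5000 nM in this assay, at which 2 of the 3 values shown sit.

Going by these compounds, it remains open whether carboxy is special at this place, or whether a simple amine, a primary amide or a nitrile on the same pyridine ring would also give a readable number in this assay. Also open, on these data alone, is how far under their shared limit compound 1 and compound 2 really lie, and so whether either step to compound 3 goes beyond the scatter.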